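The compounds below may be only part of what the source reports. "The series", "measured", "known", "first", "only" and "open" are said of these compounds alone.

In a functional assay on A549 cells (Homo sapiens) for cytotoxicity, read by MTT assay, with a stated time of 72 h (on this read-out lower numbers stand for stronger inhibition and higher numbers for weaker inhibition), compound 3 `CN(C)Cc1ccc2nc(NC(=O)N/N=C/c3cn(Cc4ccccc4)c4ccccc34)sc2c1` gives 2900 nM. That number lies within the usual scatter of the other two measured compounds, compound 1 `CCN(CC)Cc1ccc2nc(NC(=O)N/N=C/c3cn(Cc4ccc(C)cc4)c4ccccc34)sc2c1` at 1510 nM and compound 2 `CCN(CC)Cc1ccc2nc(NC(=O)N/N=C/c3cn(Cc4ccc(Cl)cc4)c4ccccc34)sc2c1` at 2940 nM. Compound 4 `CCN(CC)Cc1ccc2nc(NC(=O)N/N=C/c3cn(Cc4ccccc4)c4ccccc34)sc2c1` differs from compound 3 in one place: diethylamino in place of dimethylamino on a saturated chain carbon bound to an aromatic carbon. Within the data shown here, no measured step makes this exact change. Among the measured compounds shown here, compound 1 and compound 2 both already carry diethylamino, and the one step between them, chloro in place of methyl on an aromatic carbon, is a 1.9-fold higher number from compound 1 to compound 2 (0.29 log units; within the scatter). Compound 4 carries neither that chloro nor that methyl. No step beyond the scatter is therefore expected in this assay, and the estimate means a 1.3-fold lower number from compound 3 to compound 4 (0.12 log units; within the scatter). Compound 4 is estimated at 2200 nM, with an expected range of 1100 nM to 4300 nM.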

Compound 4, half-maximal inhibitory concentration: 3330 nM
Estimate against measurement, compound 4: 1.5-fold (0.18 log units) below; measured number inside the range.
By their numbers in this assay, from the lowest: compounds 1, 3, 2 and 4 (each within the scatter of the next, the first and the last beyond it).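

In this assay, among these compounds, diethylamino in place of dimethylamino on a saturated chain carbon bound to an aromatic carbon gives a 1.1-fold higher number from compound 3 to compound 4 (0.06 log units; within the scatter), the first direct reading of this change. Hydrogen in place of chloro on an aromatic carbon gives a 1.1-fold higher number from compound 2 to compound 4 (0.05 log units; within the scatter), whereas hydrogen in place of methyl gives a 2.2-fold higher number from compound 1 to compound 4 (0.34 log units; beyond the scatter), so only the methyl step separates two compounds here. Nothing available explains these steps. Still open, on these data alone, is how a cyclic amine such as morpholine or pyrrolidine would read in place of diethylamino, and how methoxy would read in place of chloro or methyl.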